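This account rests on a few compounds, and the source may have more. Where it says the series, first, only, none or still open, it means among the compounds named here.

Measured so far in an ADME assay on isolated protein for inhibition of Amine oxidase [flavin-containing] A (Homo sapiens), read by fluorescence and Amplex Red, with stated times of 15 min and 20 min; a lower number here means a stronger inhibitor, a higher number a weaker inhibitor:
Compound 1, `C#CCN(CCCCOc1ccc2ccc(=O)oc2c1)Cc1ccc(C(C)C)cc1`, gives 35400 nM.
Compound 2, `C#CCN(CCCCOc1ccc2ccc(=O)oc2c1)Cc1ccccc1`, gives 89400 nM.
Compound 3, `C#CCN(CCCOc1ccc2ccc(=O)oc2c1)Cc1ccccc1`, gives 38600 nM.

Compound 4, `C#CCN(CCCOc1ccc2ccc(=O)oc2c1)Cc1ccc(C(C)C)cc1`, is not yet measured. Compound 1 and compound 2 share one core and differ only by isopropyl in place of hydrogen on an aromatic carbon; in this assay that change produced a 2.5-fold lower number from compound 2 to compound 1 (0.40 log units; beyond the scatter). Compound 3 has a different core from compound 2, and the difference between the two cores is not broken down here. Among the measured compounds shown here, compound 4 arises from compound 3 by isopropyl in place of hydrogen on an aromatic carbon, which is the same change, at the same place, as the one from compound 2 to compound 1. For the measured compounds named here, for compound 4 the expected step in this assay is a 2.3-fold lower number from compound 3 to compound 4 (0.36 log units; beyond the scatter), a little more cautious than the earlier one because only one such step, a 2.5-fold lower number from compound 2 to compound 1 (0.40 log units; beyond the scatter), supports it. Compound 4 is therefore estimated at 17000 nM, most likely between 8000 nM and 36000 nM.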

Compound 4, half-maximal inhibitory concentration: 77400 nM
The estimate for compound 4 lay 4.6-fold (0.66 log units) below the measured number, outside the stated range (above it).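

In this assay, isopropyl in place of hydrogen on the core of compound 3 gave a 2.0-fold higher number from compound 3 to compound 4 (0.30 log units; within the scatter), so the clear gain seen on the other core did not carry over. The two cores respond to the same change by different amounts, and that gap is larger than repeat measurements would explain: the same change on two cores in this assay, a 2.5-fold lower number (0.40 log units; beyond the scatter) from compound 2 to compound 1 and a 2.0-fold higher number (0.30 log units; within the scatter) from compound 3 to compound 4, 5.1-fold (0.70 log units) apart, beyond the scatter of two such steps. This shows that, for these two pairs, the result of this change depends on the core, but it does not show why, and two pairs give no rule for any further core.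

The compounds shown leave open how the same change behaves on a core with a longer chain. They also leave open whether a smaller group such as methyl, or a chlorine atom, at the same place would follow isopropyl.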